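This account rests on a few compounds, and the source may have more. Where it says the series, first, only, none or still open, it means among the compounds named here.

In an assay on HeLa cells for displacement of a labelled ligand from 5-hydroxytryptamine receptor 6 (Homo sapiens) (on this read-out lower numbers stand for stronger inhibition and higher numbers for weaker inhibition), compound 1 `CC(C)N1CCCC(n2cc(S(=O)(=O)C3=C(Cl)NC4SC=CN34)c3cccnc32)C1` gives 1.7 nM, compound 2 `O=S(=O)(c1cccc(Cl)c1)c1cn(C2CCCNC2)c2ncccc12` gives 1.3 nM, and compound 3 `O=S(=O)(c1ccc(Cl)cc1)c1cn(C2CCCNC2)c2ncccc12` gives 7.6 nM. Compound 3 thus stands highest of the three numbers in this assay, with compound 1 the nearest and compound 2 the furthest away. For the measured compounds named here, the one measured step, a 5.8-fold higher number from compound 2 to compound 3 (0.77 log units; beyond the scatter), concerns the chlorophenyl group alone. Compound 4 `O=S(=O)(C1=C(Cl)NC2SC=CN12)c1cn(C2CCCNC2)c2ncccc12` differs from compound 3 by a group of 9 heavy atoms (5 carbon, 2 nitrogen, 1 sulfur, 1 chlorine; 2 five-membered non-aromatic rings with 2 hetero atoms each) in place of a group of 7 heavy atoms (6 carbon, 1 chlorine; one six-membered aromatic ring of carbon only), on a sulfonyl sulfur. Going by the values given here, no measured step covers this exchange directly, but compound 1, which carries the same entering group on its sulfonyl sulfur, gives 1.7 nM, a lower number than compound 3 beyond the scatter. A step of a 3.8-fold lower number from compound 3 to compound 4 (0.58 log units; beyond the scatter) is therefore expected. The number expected for compound 4 in this assay is 2 nM, between 0.7 nM and 6 nM.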

Compound 4, inhibition constant: 0.7 nM
Compound 4: middle estimate off by 2.9-fold (0.46 log units), on the high side; the measured number falls inside the stated range.
By their numbers in this assay, from the lowest: compounds 4, 2 and 1 (each within the scatter of the next, the first and the last beyond it); then compound 3.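

In this assay, the group from compound 1 can now be compared directly on the sulfonyl sulfur with hydrogen on the amine nitrogen: replacing 4-chlorophenyl gives an 11-fold lower number from compound 3 to compound 4 (1.04 log units; beyond the scatter), whereas replacing 3-chlorophenyl gives a 1.9-fold lower number from compound 2 to compound 4 (0.27 log units; within the scatter), so the gain depends on which chlorophenyl it replaces. The isopropyl on the amine nitrogen in a ring also enters a step, with hydrogen in its place giving a 2.4-fold lower number from compound 1 to compound 4 (0.39 log units; beyond the scatter). No evidence is available on what lies behind these differences. The compounds shown leave open how methyl or ethyl on that nitrogen would compare, and how unsubstituted phenyl or 3-fluorophenyl would fare on the sulfonyl sulfur.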